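Benzofuran in place of benzothiazole on the aryl terminus

The compounds below may be only part of what the source reports. "The series", "measured", "known", "first", "only" and "open" are said of these compounds alone.

Compound 3 `O=C(O)CCCSCCN1C(=O)CC[C@@H]1/C=C/[C@@H](O)Cc1cccc(-c2nc3ccccc3s2)c1` carries a 1,3-benzothiazol-2-yl group on the aryl terminus of the shared core; in an assay on CHO cells for displacement of a labelled ligand from prostaglandin E2 receptor EP4 subtype (Mus musculus), read by scintillation counting, with a stated time of 60 min (a higher number here means a weaker inhibitor, a lower number a stronger inhibitor), compound 3 gives 0.36 nM. Among the three measured numbers this is the second highest. The nearest is compound 2 `O=C(O)CCCSCCN1C(=O)CC[C@@H]1/C=C/[C@@H](O)Cc1cccc(-c2ccc3[nH]ccc3c2)c1`, which in this assay gives 0.28 nM; the step of a 1.3-fold higher number from compound 2 to compound 3 (0.11 log units; within the scatter) lies within the scatter. The furthest is compound 1 `O=C(O)CCCSCCN1C(=O)CC[C@@H]1/C=C/[C@@H](O)Cc1cccc(N2Cc3ccccc3C2)c1`, which in this assay gives 4.4 nM; the steps of a 16-fold lower number from compound 1 to compound 2 (1.20 log units; beyond the scatter) and a 12-fold lower number from compound 1 to compound 3 (1.09 log units; beyond the scatter) are both beyond the scatter.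

Compound 4 `O=C(O)CCCSCCN1C(=O)CC[C@@H]1/C=C/[C@@H](O)Cc1cccc(-c2cc3ccccc3o2)c1` differs from compound 3 in one place: 1-benzofuran-2-yl in place of 1,3-benzothiazol-2-yl on an aromatic carbon. The step that bears most directly on this is a 1.3-fold higher number from compound 2 to compound 3 (0.11 log units; within the scatter), an exchange of one bicyclic aromatic group for another that stayed within the scatter. Compound 4 again keeps a bicyclic aromatic group, and the large steps away from compound 1 do not apply to it. No change beyond the scatter is expected in this assay; the estimated step is a 1.1-fold higher number from compound 3 to compound 4 (0.05 log units; within the scatter). Compound 4 is expected to give 0.4 nM in this assay, with a range from 0.15 nM to 1.2 nM.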

Compound 4, inhibition constant: 0.1 nM
Compound 4: the middle estimate sits 4.0-fold (0.60 log units) above what was measured; the whole stated range lies above it.
By their numbers in this assay, from the lowest: compound 4; then compounds 2 and 3 (each within the scatter of the next); then compound 1.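

In this assay, among these compounds, this position separates bicyclic aromatic groups more finely than the earlier compounds suggested: 1-benzofuran-2-yl in place of 1,3-benzothiazol-2-yl gives a 3.6-fold lower number from compound 3 to compound 4 (0.56 log units; beyond the scatter), and in place of 1H-indol-5-yl it gives a 2.8-fold lower number from compound 2 to compound 4 (0.45 log units; beyond the scatter), whereas the exchange between those two earlier groups stayed within the scatter. Keeping the heavy-atom count and both ring sizes therefore does not make these groups interchangeable. The distance from the group with the non-aromatic five-membered ring also reaches a 44-fold lower number from compound 1 to compound 4 (1.64 log units; beyond the scatter).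

No measurement shown here accounts for the difference between these groups. From the compounds shown here alone, it remains open whether the ring oxygen itself matters, or whether 1-benzothiophen-2-yl or 1H-indol-2-yl on the same aromatic carbon would give a number like that of compound 4.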